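The source may report more compounds than this note shows. Statements on the series, on what has been measured and on what is new or still open speak of the compounds shown alone.

Measured so far in an ADME assay on A549 cells (Homo sapiens) for cytotoxicity, read by resazurin assay, with a stated time of 48 h; a higher number here means that more compound is tolerated, a lower number that less compound is tolerated:

- compound 1 `CC(C)Nc1ccc(NC(=O)c2cc(Cl)ccc2O)c(Cl)c1`: 11000 nM
- compound 2 `CCCCCCC(C)Nc1ccc(NC(=O)c2cc(Cl)ccc2O)c(Cl)c1`: 23500 nM
- compound 3 `CCN(CC)c1ccc(NC(=O)c2cc(Cl)ccc2O)c(Cl)c1`: 55500 nM

In this assay, compound 3 gives the highest number of the three, 55500 nM. The next compound to consider is compound 4 `O=C(Nc1ccc(NCc2ccc(Cl)cc2)cc1Cl)c1cc(Cl)ccc1O`, in which (4-chlorobenzyl)amino stands in place of diethylamino on an aromatic carbon: (4-chlorobenzyl)amino in place of diethylamino on an aromatic carbon.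

Among the measured compounds shown here, two measured steps bear most directly on this change: a 5.0-fold higher number from compound 1 to compound 3 (0.70 log units; beyond the scatter) and a 2.4-fold higher number from compound 2 to compound 3 (0.37 log units; beyond the scatter). In compound 1, compound 2 and compound 4, the amino nitrogen still bears a hydrogen, which it does not in compound 3. Among the measured compounds, the two with that hydrogen give the lower numbers, though two compounds make a thin basis. The step of a 2.1-fold higher number from compound 1 to compound 2 (0.33 log units; beyond the scatter) shows that the number also moves between these two compounds. None of the three measured compounds has a ring in this group, so the size of the step is uncertain. A modest fall from compound 3 is therefore expected, roughly reversing the steps above.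

The expected change is a 3.7-fold lower number from compound 3 to compound 4 (0.57 log units; beyond the scatter).

Compound 4 is estimated at 15000 nM, with an expected range of 5000 nM to 45000 nM.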

Compound 4, half-maximal cytotoxic concentration: 59700 nM
Compound 4: the middle estimate sits 4.0-fold (0.60 log units) below what was measured; the whole stated range lies below it.
By their numbers in this assay, from the lowest: compound 1; then compound 2; then compounds 3 and 4 (each within the scatter of the next).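

In this assay, the step of a 1.1-fold higher number from compound 3 to compound 4 (0.03 log units; within the scatter) shows that a nitrogen still bearing its hydrogen need not go with a lower number, since (4-chlorobenzyl)amino and diethylamino cannot be told apart at this position. The earlier link between that hydrogen and the lower numbers therefore holds only for the two alkylamino compounds, and the new compound goes against it. The steps of a 2.5-fold higher number from compound 2 to compound 4 (0.40 log units; beyond the scatter) and a 5.4-fold higher number from compound 1 to compound 4 (0.73 log units; beyond the scatter) show that, among the groups that keep the hydrogen, the number depends on what else the nitrogen carries, and that a group with a six-membered aromatic ring is tolerated here at least as well as either alkyl group; no measurement shown accounts for this.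

The compounds shown leave open whether the ring itself or its chloro group goes with this result, a question that a plain benzylamino group in the same place would address. They also leave open how a saturated cyclic amine such as morpholine, which has no hydrogen on the nitrogen and carries a ring, would compare with diethylamino.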